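Adding one methyl to compound 3

The source may hold more compounds than are shown below. What is called first, only, known or untested is meant among the compounds shown, and "the series" means these compounds.

In a functional assay on SK-OV-3 cells (Homo sapiens) for cytotoxicity (on this read-out higher numbers stand for weaker inhibition and lower numbers for stronger inhibition), compound 1 `Oc1nc(-c2ccc(C(F)(F)F)cc2)cc2ccccc12` gives 87300 nM, compound 2 `Cc1ccc(-c2cc3ccccc3c(O)n2)cc1` gives 13800 nM, and compound 3 `Cc1ccc2c(O)nc(-c3ccccc3)cc2c1` gives 1700 nM. Compound 3 thus holds the lowest number of the three, and its distance to each of the others lies beyond the scatter.

The next structure is compound 4 `Cc1ccc2c(O)nc(-c3ccccc3C)cc2c1`, which is reached from compound 3 by methyl in place of hydrogen on an aromatic carbon of a six-membered aromatic ring of carbon only, ortho to a large group.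

Among the measured compounds shown here, only one measured step is available, and it bears on this change only loosely: a 6.3-fold lower number from compound 1 to compound 2 (0.80 log units; beyond the scatter). That step is modest and exchanges trifluoromethyl for methyl, so it does not show what methyl does in place of hydrogen. For the measured compounds named here, no measured pair tests a substituent at the new place. The data therefore support no large shift in this assay, and only a small move towards a higher number is expected, possibly not beyond the scatter. The expected change is a 1.8-fold higher number from compound 3 to compound 4 (0.25 log units; within the scatter). For compound 4 the estimated value is 3000 nM, with an expected range of 800 nM to 11000 nM.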

Compound 4, half-maximal inhibitory concentration: 4270 nM
The estimate for compound 4 lay 1.4-fold (0.15 log units) below the measured number, and the stated range covers the measured number.
By their numbers in this assay, from the lowest: compound 3; then compound 4; then compound 2; then compound 1.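

In this assay, among the compounds shown here, methyl in place of hydrogen on an aromatic carbon, ortho to a large group, gives a 2.5-fold higher number from compound 3 to compound 4 (0.40 log units; beyond the scatter), and this is the first measured step that places a substituent here. The earlier step exchanged trifluoromethyl for methyl and so could not show what methyl does in place of hydrogen; this one shows that the change moves the number in the direction of weaker inhibition, by a modest amount that still lies beyond the scatter. No measurement bearing on the origin of this step is available, so the shift stands as an observation only.

The compounds shown leave open whether the size of this step is particular to methyl, or whether a chlorine atom, a methoxy group, an amine, a carboxylic acid or a longer chain at the same place would move the number further, less or the other way. They also leave open whether the step would keep its direction and size on a core without the methyl that compound 3 and compound 4 share.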